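The source may report more compounds than this note shows. Statements on the series, on what has been measured and on what is new or still open speak of the compounds shown alone.

Measured compounds:
Compound 1, `CN(C)Cc1ccc2nc(NC(=O)N/N=C3\C(=O)Nc4ccc(F)cc43)sc2c1`: 1550 nM
Compound 2, `O=Cc1cn(Cc2ccc(Cl)cc2)c2ccccc12`: 850 nM

Both compounds were tested in a functional assay on NCI-H460 cells (Homo sapiens) for cytotoxicity, read by MTT assay, with a stated time of 72 h; a higher number here means a weaker inhibitor, a lower number a stronger inhibitor. Compound 1 gives 1550 nM in this assay. Compound 2 shares no obvious part of its structure with compound 1; in this assay compound 2 gives 850 nM. The two numbers differ by less than the usual scatter of repeated measurements, so nothing can be said about which of the two is the stronger inhibitor; compound 1 simply has the higher of the two values as they stand.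

For the measured compounds named here, the next compound, compound 3, `CCN(CC)Cc1ccc2nc(NC(=O)N/N=C3\C(=O)Nc4ccc(F)cc43)sc2c1`, keeps the whole core of compound 1 and changes only one small group. The difference is diethylamino in place of dimethylamino on a saturated chain carbon bound to an aromatic carbon. The chain grows by two carbons while the count of hydrogen-bond donors and acceptors stays the same, and no ring or charge is gained or lost. Going by the values given here, nothing among the measured compounds shows the effect of such a change, so the expectation rests on its small size alone. The step from compound 1 to compound 3 is expected to be a 1.0-fold lower number from compound 1 to compound 3 (0.01 log units; within the scatter), that is, no change beyond the scatter. Compound 3 is therefore estimated at 1500 nM in this assay, with a likely range from 600 nM to 4000 nM.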

Compound 3, half-maximal inhibitory concentration: 1060 nM
Compound 3: middle estimate off by 1.4-fold (0.15 log units), on the high side; the measured number falls inside the stated range.
By their numbers in this assay, from the lowest: compounds 2, 3 and 1 (each within the scatter of the next).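

For the compounds shown here, the change from dimethylamino to diethylamino, on a saturated chain carbon bound to an aromatic carbon, is the first that can be read on its own here, since everything else in the two compounds is the same. In this assay it amounts to a 1.5-fold lower number from compound 1 to compound 3 (0.17 log units; within the scatter), so neither group can be called better, and the larger diethylamino group is accepted at this place without a clear gain or loss. Nothing measured here offers an explanation for this result, which remains an observation about a single pair of compounds.

The compounds shown leave open whether this place responds to anything more than a small change in the amine, and a carboxylic acid or a plain methyl group in place of the amine would put that to the test. Also open, as far as these compounds go, is what would happen with a piperidine ring, which would tie the two ethyl arms into a ring, or with a longer chain leading to the same diethylamino group.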